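A few compounds are considered here, and "the series" means these few. Any claim that something is new, unique, unknown or untested is made for them only; others in the source may bear on it.

Measured compounds in an assay on CHO cells for displacement of a labelled ligand from adenosine receptor A3 (Homo sapiens), read by scintillation counting, tested at 10 uM; on this read-out lower numbers stand for less inhibition and higher numbers for more inhibition at the one concentration tested (going by the name of the read-out):

- compound 1 `CC(C)(C)Cc1c(-c2cccnc2)sc(N)c1C(=O)c1ccc(Cl)cc1`: 1%
- compound 2 `COc1cccc(-c2sc(N)c(C(=O)c3ccc(Cl)cc3)c2CC(C)(C)C)c1`: 1%
- compound 3 `Cc1ccccc1-c1sc(N)c(C(=O)c2ccc(Cl)cc2)c1CC(C)(C)C`: 1%

All three share one core and differ only in the aryl group on the ring carbon next to the ring sulfur. In this assay compound 3 stands level with compound 1 and compound 2 at the digits shown; the step of no change at the digits printed from compound 1 to compound 3 (within the scatter) and the step of no change at the digits printed from compound 2 to compound 3 (within the scatter) are both flat, as is no change at the digits printed from compound 1 to compound 2 (within the scatter). Going by the values given here, nothing among the measured compounds separates the three aryl groups from one another.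

The next compound is compound 4 `CC(C)c1ccc(-c2sc(N)c(C(=O)c3ccc(Cl)cc3)c2CC(C)(C)C)cc1`. Relative to compound 3 the change is 4-isopropylphenyl in place of 2-methylphenyl on an aromatic carbon, a third variation of the same aryl group in the same place.

Among the compounds with values here, the steps that bear on it are no change at the digits printed from compound 1 to compound 3 (within the scatter) and no change at the digits printed from compound 2 to compound 3 (within the scatter), neither of which moved the read-out. With three aryl groups giving the same figure, no direction is suggested for a fourth; the expectation for a number 1 percentage points higher from compound 3 to compound 4 (within the scatter) is therefore no step beyond the scatter. Compound 4 is estimated to give about 2% in this assay, with a range from -6% to 12%.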

Compound 4, a percentage reported as inhibition, at one concentration (the size of the read-out at that concentration, not a potency): 1%
Compound 4: the middle estimate sits 1 percentage points above what was measured, within the range that was stated.
By their numbers in this assay, from the lowest: compounds 1, 2, 3 and 4 (each within the scatter of the next).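

In this assay, 4-isopropylphenyl, with 9 heavy atoms in place of the 7 of 2-methylphenyl, gives no change at the digits printed from compound 3 to compound 4 (within the scatter), and comparison with the other two aryl groups gives no change at the digits printed from compound 2 to compound 4 (within the scatter) and no change at the digits printed from compound 1 to compound 4 (within the scatter). The flat result at this position, on the aromatic carbon next to the ring sulfur, therefore now extends to a 4-isopropylphenyl group, with compound 4 at 1% in this assay; across these four compounds, neither this change nor the earlier aryl changes separate one group from another. No measurement available here accounts for this flat result.

As far as these compounds go, whether a different kind of group on this carbon, such as a carboxylic acid, a piperazine or a longer alkyl chain, would shift the read-out remains open. Also open, from the compounds shown here alone, is whether changing the neopentyl, (4-chlorophenyl)carbonyl or amino groups, which are constant across these compounds, would move the read-out away from the values seen here.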